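Three compounds at the limit, one still unmeasured

The compounds below may be only part of what the source reports. "The series", "measured", "known", "first", "only" and "open" are said of these compounds alone.

Measured so far in a functional assay on MOLT-4 cells (Homo sapiens) for inhibition, read by sulforhodamine B assay, with a stated time of 48 h; a higher number here means that more compound is tolerated, a lower number that less compound is tolerated:
compound 1 `COc1cc(-c2cc(/C=C/C(=O)c3ccc(N)cc3)[nH]n2)cc(OC)c1OC` gives > 100000 nM, a limit of the assay and not a number.
compound 2 `COc1ccc(-c2cc(/C=C/C(=O)c3ccc(N)cc3)[nH]n2)cc1OC` gives > 100000 nM, likewise a limit.
compound 3 `COc1cc(C(=O)/C=C/c2cc(-c3cc(OC)c(OC)c(OC)c3)n[nH]2)cc(OC)c1OC` gives > 100000 nM, again a limit.

In this assay none of the three compounds yields a number. The step from compound 1 to compound 2 is a step that the two limits leave unreadable from compound 1 to compound 2; the change is hydrogen in place of methoxy on an aromatic carbon and, with both ends sitting at a limit, nothing can be said about how large the step is. How the core of compound 3 differs from the core of compound 1 is not broken down here. The one thing the data offer is the limit of > 100000 nM in this assay, at which 3 of the 3 values shown sit, which holds for every value shown.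

Compound 4 `COc1ccc(-c2cc(/C=C/C(=O)c3cc(OC)c(OC)c(OC)c3)[nH]n2)cc1OC` has not yet been measured in this assay. It is related to compound 3 by hydrogen in place of methoxy on an aromatic carbon, the same change that leads from compound 1 to compound 2, and the surroundings of the place are described in the same words in both cases. That earlier step could not be read, so it gives no guide to a direction. Because the limit of > 100000 nM in this assay, at which 3 of the 3 values shown sit, is where all three measured values rest, compound 4 is expected to end up at or near that limit as well, with a step that the limit leaves unreadable from compound 3 to compound 4 as the expected step from compound 3 to compound 4. For compound 4 the estimate in this assay is 150000 nM, expected to fall between 50000 nM and 500000 nM, most likely reported as a limit rather than a number.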

Compound 4, concentration lethal to 50% of the cells: > 100000 nM
Compound 4: a limit, no number; the forecaster's own chance of this, stated with the estimate: 85%; the middle value lies beyond the limit too.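

In this assay compound 4 gives > 100000 nM, which is a limit of the assay and not a number. With compound 3 and compound 4 both resting at a limit, no new step can be read between them. The compounds shown leave open how far each lies past the limit and whether any change among them alters the reading at all: the limit of > 100000 nM in this assay, at which 4 of the 4 values shown sit.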